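Adding a second chloro to compound 3

This account rests on a few compounds, and the source may have more. Where it says the series, first, only, none or still open, it means among the compounds named here.

In a functional assay on HL-60 cells (Homo sapiens) for cytotoxicity, read by WST assay, with a stated time of 48 h (on this read-out higher numbers stand for an effect only at larger amounts of compound and lower numbers for an effect already at smaller amounts), compound 1 (`Cc1ccccc1C[C@H]1C(=O)OC[C@@H]1Cc1ccccc1`) gives 57000 nM, compound 2 (`O=C1OC[C@H](Cc2ccccc2)[C@H]1Cc1ccccc1Cl`) gives 37000 nM and compound 3 (`O=C1OC[C@H](Cc2ccccc2)[C@H]1Cc1ccc(Cl)cc1`) gives 36000 nM. All three lie within the scatter of one another, so compound 3 stands level with both. Compound 4 (`O=C1OC[C@H](Cc2ccccc2)[C@H]1Cc1ccc(Cl)cc1Cl`) differs from compound 3 by one change: chloro in place of hydrogen on an aromatic carbon, ortho to a large group and meta to a chloro group. The closest measured steps are a 1.0-fold lower number from compound 2 to compound 3 (0.01 log units; within the scatter) and a 1.5-fold lower number from compound 1 to compound 2 (0.19 log units; within the scatter), and both stay within the scatter. Among the measured compounds shown here, no measured compound carries two chloro groups, so this guide is indirect. No step beyond the scatter is expected, and the expected size is a 1.2-fold lower number from compound 3 to compound 4 (0.08 log units; within the scatter). For compound 4 the estimated value is 30000 nM, with an expected range of 14000 nM to 60000 nM.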

Compound 4, half-maximal effective concentration: 19000 nM
Compound 4: the middle estimate sits 1.6-fold (0.20 log units) above what was measured, and the stated range covers the measured number.
By their numbers in this assay, from the lowest: compounds 4, 3, 2 and 1 (each within the scatter of the next, the first and the last beyond it).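

In this assay, a chloro on the aromatic carbon ortho to a large group and meta to a chloro group gives a 1.9-fold lower number from compound 3 to compound 4 (0.28 log units; within the scatter) and, counted from the other compound with one chloro, the step is a 1.9-fold lower number from compound 2 to compound 4 (0.29 log units; within the scatter) in the same assay. Both steps stay within the scatter, so a second chloro on this ring is tolerated but cannot be told apart from a single one. No measurement here bears on the reason for these numbers.

Still open, on these data alone, is whether another group at this position, such as an amine or a methoxy, would move the number beyond the scatter.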